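The source may report more compounds than this note shows. Statements on the series, on what has been measured and on what is new or still open speak of the compounds shown alone.

Compound 1 `CCNC(=O)[C@H]1O[C@@H](n2cnc3c(NNC(=O)c4ccc(Cl)cc4)ncnc32)[C@H](O)[C@@H]1O` and compound 2 `CCNC(=O)[C@H]1O[C@@H](n2cnc3c(NNC(=O)c4ccc(Br)o4)ncnc32)[C@H](O)[C@@H]1O` share one core and differ only in the group on the carbonyl carbon. In an assay on CHO cells for displacement of a labelled ligand from adenosine receptor A1 (Homo sapiens) (a lower number here means a stronger inhibitor, a higher number a weaker inhibitor), compound 1 reaches only the limit of the assay, > 5000 nM. In this assay compound 2 gives 780 nM. Within the data shown here, the step of an at least 6.4-fold lower number from compound 1 to compound 2 (0.80 log units; beyond the scatter) is the only measured step, and compound 2 holds the only real number, the other value being a limit (the limit of > 5000 nM in this assay, at which 1 of the 2 values shown sits). Compound 3 `CCNC(=O)[C@H]1O[C@@H](n2cnc3c(NNC(=O)c4ccc(C)o4)ncnc32)[C@H](O)[C@@H]1O` keeps the furan ring of compound 2 and carries methyl in place of bromo on an aromatic carbon. The step from compound 1 to compound 2 swapped the whole ring along with its halogen, so it speaks only loosely to a change that keeps the ring and replaces bromo with methyl; a step in this assay of modest size in either direction, or none beyond the scatter, is expected, most likely towards a slightly higher number. Compound 3 is therefore estimated at 1500 nM, within 500 nM to 5000 nM, which amounts to an expected 1.9-fold higher number from compound 2 to compound 3 (0.28 log units; within the scatter).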

Compound 3, inhibition constant: 700 nM
For compound 3 the middle estimate is 2.1-fold (0.33 log units) above the measured one; the range from low to high includes it.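

In this assay, replacing bromo with methyl on the carbon next to the ring oxygen gives a 1.1-fold lower number from compound 2 to compound 3 (0.05 log units; within the scatter) and so, at this position, the two groups cannot be told apart. The furan compounds stay clear of the 4-chlorophenyl compound whichever of the two groups is present, with an at least 7.1-fold lower number from compound 1 to compound 3 (0.85 log units; beyond the scatter) as the new step, so the earlier step did not rest on the bromine alone. The true size of that step remains unknown, because compound 1 has only a limit of the assay and not a number: the limit of > 5000 nM in this assay, at which 1 of the 3 values shown sits.

The compounds shown leave open how a hydrogen, an amine, a carboxylic acid or a longer chain such as propyl would behave at this position. They also leave open whether a 4-methylphenyl group would read closer to compound 1 or to compound 3.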